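Aryl swap on the piperazine of aminothiophene ketones

The compounds below may be only part of what the source reports. "The series", "measured", "known", "first", "only" and "open" are said of these compounds alone.

Measured so far:
compound 1 `Nc1scc(CN2CCN(c3cccc(C(F)(F)F)c3)CC2)c1C(=O)c1ccc(Cl)cc1` — -30%
compound 2 `Nc1scc(CN2CCN(c3cccc(F)c3)CC2)c1C(=O)c1cccc(C(F)(F)F)c1` — -12%

Going by the values given here, in a functional assay on CHO cells with adenosine receptor A1 (Homo sapiens) as the target, read by cAMP accumulation and immunoassay, with a stated time of 6 min, tested at 0.1 uM (a higher number here means a weaker effect of the compound at the concentration tested, a lower number a stronger effect), compound 1 gives -30%, the lowest of the two numbers known. Among the compounds with values here, compound 2 gives -12%, a number higher than compound 1 by more than the scatter; compound 2 differs from compound 1 in more than one place, so no single step is drawn between them. Compound 3 `Nc1scc(CN2CCN(c3ccccc3F)CC2)c1C(=O)c1ccc(Cl)cc1` is not yet measured. It differs from compound 1 as follows: 2-fluorophenyl in place of 3-(trifluoromethyl)phenyl on an amine nitrogen in a ring. Within the data shown here, no measured step of this kind exists, so the expected step of a number 12 percentage points higher from compound 1 to compound 3 (beyond the scatter) is small, toward a weaker effect, and may lie within the scatter. Compound 3 is expected to give -18%, with a range from -45% to 8%.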

Compound 3, a percentage reported as activity, at one concentration (the size of the read-out at that concentration, not a potency): -1%
For compound 3 the middle estimate is 17 percentage points below the measured one, within the range that was stated.
By their numbers in this assay, from the lowest: compound 1; then compound 2; then compound 3.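

Going by these compounds alone, replacing 3-(trifluoromethyl)phenyl with 2-fluorophenyl on the amine nitrogen in the ring gives the only single-place step in this assay: a number 29 percentage points higher from compound 1 to compound 3 (beyond the scatter). The group at this position therefore affects the read-out at the concentration tested, which compound 1 and compound 2 could not show. No measurement given here accounts for the step.

From the compounds shown here alone, whether the substituent or its place on the phenyl ring matters remains open, as both change together. Going by these compounds, how an unsubstituted phenyl or a methoxyphenyl would read at this position also remains open.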